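The source may hold more compounds than are shown below. What is called first, only, known or untested is meant among the compounds shown, and "the series" means these compounds.

Measured so far in a physicochemical assay for lipophilicity, at pH 7.4 (a lower number here means a more polar compound, a higher number a more lipophilic compound), for this series:

- compound 1 `CC(C)CN(c1ccc(F)cc1)S(=O)(=O)c1ccc2c(c1)C(O)CC(C1CCOCC1)O2` at 3.39
- compound 2 `CC(C)CN(c1cccc(F)c1)S(=O)(=O)c1ccc2c(c1)C(O)CC(C1CCOCC1)O2` at 3.39

Among the measured compounds shown here, compound 2 stands at 3.39 and is level with compound 1, and no other compound has a number yet. In compound 3 `CC(C)CN(Cc1ccccc1C(F)(F)F)S(=O)(=O)c1ccc2c(c1)C(O)CC(C1CCOCC1)O2` the change from compound 2 is 2-(trifluoromethyl)benzyl in place of 3-fluorophenyl on a sulfonamide nitrogen and it sets 2-(trifluoromethyl)benzyl in place of 3-fluorophenyl on a sulfonamide nitrogen. For the measured compounds named here, only one measured step bears on this, no change at the digits printed from compound 1 to compound 2 (within the scatter) and it stays within the scatter. That step swapped 3-fluorophenyl for 4-fluorophenyl at the same place, so it offers little guidance on a change of this kind. Going by the values given here, no measured compound carries a benzyl group on this nitrogen, and none carries a trifluoromethyl group. The expectation therefore starts from compound 2 at 3.39 and rests on judgement of the structural change alone, which points to a moderate rise in this assay with a wide margin. The expected move is upward, estimated as a number 0.41 log units higher from compound 2 to compound 3 (beyond the scatter) in size. For compound 3 the estimate is 3.8 with 3.3 to 4.3 as the expected range.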

Compound 3, distribution coefficient: 4.23
Estimate against measurement, compound 3: 0.43 log units below; the range from low to high includes it.
By their numbers in this assay, from the lowest: compounds 1 and 2 (each within the scatter of the next); then compound 3.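

In this assay, among the compounds shown here, the sulfonamide nitrogen proves to be a place where the number can shift: the only earlier change there, 3-fluorophenyl for 4-fluorophenyl, gave no change at the digits printed from compound 1 to compound 2 (within the scatter), whereas 2-(trifluoromethyl)benzyl in place of 3-fluorophenyl gives a number 0.84 log units higher from compound 2 to compound 3 (beyond the scatter), and in place of 4-fluorophenyl gives a number 0.84 log units higher from compound 1 to compound 3 (beyond the scatter). The two fluorophenyl compounds thus serve as one level from which the new group moves the read-out by the same printed amount, with 11 heavy atoms entering where 7 leave, and with the count of hydrogen-bond donors, hydrogen-bond acceptors and net charge the same in the groups that leave and enter. No measurement in hand explains the rise.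

The step alters the group on the nitrogen in more than one way at once, replacing a phenyl with a benzyl and a fluorine with a trifluoromethyl, so these compounds cannot separate the share of each. On these data alone, how an unsubstituted benzyl group, or a benzyl group carrying a carboxylic acid or an amine, would stand in this assay stays open.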